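Three Acylurea Hydrazones and a Fourth to Be Measured

The source may hold more compounds than are shown below. What is called first, only, known or untested is meant among the compounds shown, and "the series" means these compounds.

Measured so far in a functional assay on HeLa cells (Homo sapiens) for inhibition, read by MTT assay, with a stated time of 72 h; a lower number here means a stronger inhibitor, a higher number a weaker inhibitor:
compound 1 `CN(C(=O)NC(=O)c1cccc(C(F)(F)F)c1)c1nc(C(F)(F)F)c(C(=O)N/N=C/c2cccc(C(F)(F)F)c2)s1` gives 4.81 ug/mL
compound 2 `CN(C(=O)NC(=O)c1ccc(F)c(F)c1)c1nc(C(F)(F)F)c(C(=O)N/N=C/c2cccc(C(F)(F)F)c2)s1` gives 4.21 ug/mL
compound 3 `CN(C(=O)NC(=O)c1ccc(F)c(F)c1)c1nc(C(F)(F)F)c(C(=O)N/N=C/c2cc(C(F)(F)F)cc(C(F)(F)F)c2)s1` gives 4.45 ug/mL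

Compound 3 stands second highest of the three numbers in this assay, with compound 2 nearest and compound 1 furthest, both within the scatter, so the three compounds cannot be told apart on these numbers. Compound 4 `CN(C(=O)NC(=O)c1cccc(C(F)(F)F)c1)c1nc(C(F)(F)F)c(C(=O)N/N=C/c2cc(C(F)(F)F)cc(C(F)(F)F)c2)s1` has not been measured. It differs from compound 3 in one place: 3-(trifluoromethyl)phenyl in place of 3,4-difluorophenyl on a carbonyl carbon. The same exchange, run the other way at the same carbonyl carbon, is the step from compound 1 to compound 2, which gave a 1.1-fold lower number from compound 1 to compound 2 (0.06 log units; within the scatter). The other step, a 1.1-fold higher number from compound 2 to compound 3 (0.02 log units; within the scatter), sits elsewhere and also stays within the scatter. Compound 4 is therefore expected to show no step beyond the scatter, so that a 1.1-fold higher number from compound 3 to compound 4 (0.04 log units; within the scatter) is the estimated change. On this basis compound 4 is estimated at 4.9 ug/mL in this assay, with a range from 2.5 ug/mL to 9.5 ug/mL.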

Compound 4, half-maximal inhibitory concentration: 5.34 ug/mL
Compound 4: the middle estimate sits 1.1-fold (0.04 log units) below what was measured; measured number inside the range.
By their numbers in this assay, from the lowest: compounds 2, 3, 1 and 4 (each within the scatter of the next).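

In this assay, placing 3-(trifluoromethyl)phenyl in place of 3,4-difluorophenyl on a carbonyl carbon gives a 1.2-fold higher number from compound 3 to compound 4 (0.08 log units; within the scatter), so an exchange earlier seen on one core now stands on a second, and it stays small on both: the same change on two cores in this assay, a 1.1-fold lower number (0.06 log units; within the scatter) from compound 1 to compound 2 and a 1.2-fold lower number (0.08 log units; within the scatter) from compound 4 to compound 3, 1.1-fold (0.02 log units) apart, within the scatter of two such steps

The added trifluoromethyl on an aromatic carbon likewise gives a 1.1-fold higher number from compound 1 to compound 4 (0.05 log units; within the scatter), and this change too now holds on two cores: the same change on two cores in this assay, a 1.1-fold higher number (0.02 log units; within the scatter) from compound 2 to compound 3 and a 1.1-fold higher number (0.05 log units; within the scatter) from compound 1 to compound 4, 1.1-fold (0.02 log units) apart, within the scatter of two such steps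

Neither exchange therefore produces a step beyond the scatter on either core.

All the groups shown on this carbonyl carbon are fluorinated phenyl rings, so it remains open whether an amine or a carboxylic acid on that ring, or a longer alkyl chain in its place, would move the number beyond the scatter. Nor do the compounds shown tell whether these steps would stay as small outside this assay.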